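The source may hold more compounds than are shown below. What is called first, only, known or untested is meant among the compounds shown, and "the series" means these compounds.

Measured compounds and their values in a functional assay on CHO-K1 cells for antagonist activity at adenosine receptor A1 (Homo sapiens), read by a beta-galactosidase reporter and cAMP accumulation, with stated times of 15 min and 6 h; a higher number here means a weaker inhibitor, a lower number a stronger inhibitor:

compound 1 `Cc1csc(-c2nc(N)c3cc(Cc4ccccc4F)sc3n2)n1` gives 28.6 nM
compound 2 `Cc1nc(-c2nc(N)c3cc(Cc4ccccc4)sc3n2)cs1` gives 263 nM
compound 3 `Nc1nc(-c2ccccc2)nc2sc(-c3ccccc3)cc12` gives 237 nM

Compound 2 stands highest of the three numbers in this assay. Its nearest neighbour is compound 3, whose number is lower by a gap that lies within the scatter, so the two compounds cannot be ordered against each other. The only separation beyond the scatter is to compound 1, whose number is lower by a gap that lies beyond the scatter, and compound 1 differs from compound 2 at two places, so no single structural change is isolated by the measured set.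

Compound 4 `N#Cc1cncc(-c2nc(N)c3cc(Cc4ccccc4)sc3n2)c1` is the next compound to be measured. It keeps the core of compound 2 and changes the group on the aromatic carbon of the six-membered aromatic ring with 2 nitrogen that is part of the fused system:

5-cyanopyridin-3-yl in place of 2-methyl-1,3-thiazol-4-yl on an aromatic carbon

For the measured compounds named here, no step of this kind is available among the measured compounds. Since compound 2 and compound 3 carry different groups at this carbon and still give values within the scatter of each other, the expectation in this assay is a step of no clear direction and no size beyond the scatter, as a 1.1-fold higher number from compound 2 to compound 4 (0.06 log units; within the scatter). Compound 4 is therefore estimated at 300 nM, with a range from 80 nM to 1200 nM.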

Compound 4, inhibition constant: 1160 nM
Compound 4: middle estimate off by 3.9-fold (0.59 log units), on the low side, within the range that was stated.
By their numbers in this assay, from the lowest: compound 1; then compounds 3 and 2 (each within the scatter of the next); then compound 4.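

In this assay, for the compounds shown here, 5-cyanopyridin-3-yl in place of 2-methyl-1,3-thiazol-4-yl gives a 4.4-fold higher number from compound 2 to compound 4 (0.64 log units; beyond the scatter) and is the first single-place step, showing that this aromatic carbon between two ring nitrogen atoms is sensitive to the group it carries. The two groups match in their counts of hydrogen-bond donors and acceptors and in having no net charge, so the step comes with a change in ring size, ring hetero atoms, heavy-atom count and the added triple bond, not with a change in those counts. No measurement on hand bears on the reason for this step.

This one step cannot show whether the six-membered ring or the nitrile accounts for the higher number, a question that a pyridine ring with no nitrile, or one with an amine or a carboxylic acid in the nitrile's place, would address. Going by these compounds alone, how the group at this carbon relates to the fluorine on the benzyl ring of compound 1 also remains open, as compound 1 differs from compound 2 at two places and no single-place step isolates either change.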